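This account rests on a few compounds, and the source may have more. Where it says the series, first, only, none or still open, it means among the compounds named here.

Measured in a physicochemical assay for lipophilicity, read by HPLC, using the shake flask method; on this read-out higher numbers stand for higher lipophilicity and lower numbers for lower lipophilicity:
- compound 1 `CCCCC/C(=N\C#N)N(C)Cc1ccc(Cl)nc1`: 2.3
- compound 2 `CCCC/C(=N\C#N)N(C)Cc1ccc(Cl)nc1`: 1.87

Compound 2 holds the lower of the two numbers, with compound 1 the higher one. Compound 3 `CC(C)/C(=N\C#N)N(C)Cc1ccc(Cl)nc1` follows from compound 2 by isopropyl in place of butyl on a carbon with a double bond to nitrogen. For the measured compounds named here, only one measured step bears on this: a number 0.43 log units lower from compound 1 to compound 2 (beyond the scatter), a modest change on the same chain. Going by the values given here, no measured step covers a branched group, so the estimate leans on that step alone. A downward move of similar size in this assay is expected, estimated as a number 0.47 log units lower from compound 2 to compound 3 (beyond the scatter). Compound 3 is estimated at 1.4, within 1.1 to 1.7.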

Compound 3, partition coefficient: 1.39
Beside the measured number, compound 3's estimate is 0.01 log units above it; low and high end bracket the measured number.
By their numbers in this assay, from the lowest: compound 3; then compound 2; then compound 1.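

In this assay a branched group now sits on a carbon with a double bond to nitrogen, and the number falls further: isopropyl in place of butyl gives a number 0.48 log units lower from compound 2 to compound 3 (beyond the scatter) and isopropyl in place of pentyl gives a number 0.91 log units lower from compound 1 to compound 3 (beyond the scatter) at the same place. Compound 3 stands lowest of the three, but isopropyl differs from both chains in carbon count as well as in branching, so the two are not separated. No measured evidence accounts for these steps.

Going by these compounds, a straight propyl chain, with the carbon count of isopropyl, would separate them, and that reading remains open. Also open, on these data alone, is how a cyclopropyl group or a chain ending in an amine would read here.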